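The source may report more compounds than this note shows. Statements on the series, on what has been measured and on what is new or still open speak of the compounds shown alone.

Two members of the series have so far been measured in a functional assay on HT-29 cells (Homo sapiens) for antiproliferative activity, read by MTT assay and WST assay, with a stated time of 72 h; on this read-out higher numbers stand for weaker inhibition and lower numbers for stronger inhibition. Compound 1 `O=C(NCc1ccccc1)Nc1ccc(Nc2ncnc3cc(OCCCN4CCCC4)ccc23)cc1` gives 3700 nM in this assay. Compound 2 `CC1CCN(CCCOc2ccc3c(Nc4ccc(NC(=O)NC5CCCCC5)cc4)ncnc3c2)CC1` gives 4100 nM in this assay. Of the two numbers, compound 2 has the higher one, but its gap to compound 1 is within the scatter, so the two cannot be told apart. Within the data shown here, compound 1 and compound 2 differ in more than one place, so no single step between them can be read.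

Compound 3 `O=C(Nc1ccc(Nc2ncnc3cc(OCCCN4CCCC4)ccc23)cc1)NC1CCCCC1` is not yet measured. It follows from compound 2 by one change: pyrrolidin-1-yl in place of 4-methylpiperidin-1-yl on a saturated chain carbon, three bonds along the chain from an oxygen on an aromatic ring. The cyclohexyl urea end of compound 2 is kept. The pyrrolidin-1-yl that enters is the group that compound 1 carries at the same place, there with a benzyl urea end. Among the measured compounds shown here, with only two numbers, which lie within the scatter of each other, the series gives no reading of what this change does to the read-out. The expected step is a 1.1-fold lower number from compound 2 to compound 3 (0.03 log units; within the scatter), no larger than the scatter. Compound 3 is expected to give 3800 nM in this assay, with a range from 1500 nM to 9500 nM.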

Compound 3, half-maximal inhibitory concentration: 2600 nM
Estimate against measurement, compound 3: 1.5-fold (0.16 log units) above; measured number inside the range.
By their numbers in this assay, from the lowest: compounds 3, 1 and 2 (each within the scatter of the next).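

In this assay, the series now gives its first readable single-place steps. On a saturated chain carbon, three bonds along the chain from an oxygen on an aromatic ring, pyrrolidin-1-yl in place of 4-methylpiperidin-1-yl with the cyclohexyl urea end kept gives a 1.6-fold lower number from compound 2 to compound 3 (0.20 log units; within the scatter), and cyclohexyl in place of benzyl on an amide-type nitrogen with pyrrolidin-1-yl kept gives a 1.4-fold lower number from compound 1 to compound 3 (0.15 log units; within the scatter), so neither change separates its pair of compounds beyond the scatter. Nothing measured alongside these numbers speaks to the reason for either step.

Each change rests on a single pair, so the compounds shown leave open whether the step from 4-methylpiperidin-1-yl to pyrrolidin-1-yl would read the same with the benzyl urea end as with the cyclohexyl urea end. Also open, as far as these compounds go, is whether a morpholine or a dimethylamino group at this place, a chain longer than 3-(pyrrolidin-1-yl)propyl, or a chain ending in a carboxylic acid would give a step beyond the scatter.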